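Carbamate extension on the ring nitrogen: methoxycarbonyl to allyloxycarbonyl

A few compounds are considered here, and "the series" means these few. Any claim that something is new, unique, unknown or untested is made for them only; others in the source may bear on it.

Measured compounds in an assay on IMR-32 cells for inhibition of Voltage-dependent N-type calcium channel subunit alpha-1B (Homo sapiens); on this read-out lower numbers stand for stronger inhibition and higher numbers for weaker inhibition:
compound 1, `O=C(N[C@@H](CSCC1CCCCC1)C(=O)NCc1ccc(Oc2ccccc2)cc1)[C@@H]1CSCN1`, gives 290 nM;
compound 2, `COC(=O)N1CSC[C@H]1C(=O)N[C@@H](CSCC1CCCCC1)C(=O)NCc1ccc(Oc2ccccc2)cc1`, gives 120 nM.

Compound 2 stands at the lowest of the two numbers in this assay; the nearest is compound 1, and the step of a 2.4-fold lower number from compound 1 to compound 2 (0.38 log units; beyond the scatter) lies beyond the scatter.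

Compound 3, `C=CCOC(=O)N1CSC[C@H]1C(=O)N[C@@H](CSCC1CCCCC1)C(=O)NCc1ccc(Oc2ccccc2)cc1`, is not yet measured. It differs from compound 2 by vinyl in place of hydrogen on a saturated chain carbon bound to an oxygen next to a carbonyl group; cut one bond further out, this reads methoxycarbonyl to allyloxycarbonyl.

Going by the values given here, the only measured step, a 2.4-fold lower number from compound 1 to compound 2 (0.38 log units; beyond the scatter), concerns adding the carbamate itself, not lengthening its alkoxy part, so it bears on the present change only loosely. Among the compounds with values here, no measured step addresses the alkoxy chain. For compound 3 the step of a 1.1-fold lower number from compound 2 to compound 3 (0.04 log units; within the scatter) is therefore expected to stay within the scatter. Compound 3 is estimated at 110 nM, with a range of 45 nM to 280 nM.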

Compound 3, half-maximal inhibitory concentration: 330 nM
Compound 3: the middle estimate sits 3.0-fold (0.48 log units) below what was measured; measured number above the stated range.
By their numbers in this assay, from the lowest: compound 2; then compounds 1 and 3 (each within the scatter of the next).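

In this assay, the alkoxy part of the carbamate on the ring nitrogen turns out to matter: methoxy to allyloxy gives a 2.8-fold higher number from compound 2 to compound 3 (0.44 log units; beyond the scatter) and so takes back the advantage seen with methoxycarbonyl. The carbamate as such is therefore not enough, since the step of a 1.1-fold higher number from compound 1 to compound 3 (0.06 log units; within the scatter) shows that allyloxycarbonyl on that nitrogen cannot be told apart from hydrogen. No supporting data are at hand to explain the difference between methoxycarbonyl and allyloxycarbonyl.

From the compounds shown here alone, it remains open whether this step depends on the length of the alkoxy chain or on its double bond, a distinction that a saturated propoxycarbonyl group would settle. Also open, going by these compounds, is whether the carbamate oxygen is needed at all, which an acetyl group on the ring nitrogen would test.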